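Methoxy for chloro on the anilino ring of compound 2

The compounds below may be only part of what the source reports. "The series", "measured", "known", "first", "only" and "open" are said of these compounds alone.

Of the compounds shown here, two sharing one core have been measured in an assay on isolated protein for inhibition of Dihydrofolate reductase (Homo sapiens), read by spectrophotometry; on this read-out lower numbers stand for stronger inhibition and higher numbers for weaker inhibition. Compound 1 `CCN(Cc1nc2cc(C(F)(F)F)ccc2nc1-c1ccccc1)c1ccc(OC)cc1` gives 7000 nM in this assay. Compound 2 `C#CCN(Cc1nc2cc(C(F)(F)F)ccc2nc1-c1ccccc1)c1ccc(Cl)cc1` gives 4000 nM in this assay; the two numbers lie within the usual scatter of each other, so no order between compound 1 and compound 2 can be read from them. Among the measured compounds shown here, compound 1 and compound 2 differ in two places at once, on the nitrogen substituent and on the aromatic ring, and no single-change step between measured compounds is available.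

Compound 3 `C#CCN(Cc1nc2cc(C(F)(F)F)ccc2nc1-c1ccccc1)c1ccc(OC)cc1` has not been measured. It differs from compound 2 by methoxy in place of chloro on an aromatic carbon. Nothing measured isolates this change. Since compound 1, which also carries methoxy, gives 7000 nM and compound 2 gives 4000 nM, the change is expected to move the number by no more than the scatter, with the step from a 1.4-fold higher number from compound 2 to compound 3 (0.14 log units; within the scatter) estimated as small and slightly toward weaker inhibition. Compound 3 is accordingly expected to give 5500 nM in this assay, with a range of 2500 nM to 12000 nM.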

Compound 3, inhibition constant: 3000 nM
For compound 3 the middle estimate is 1.8-fold (0.26 log units) above the measured one, and the stated range covers the measured number.
By their numbers in this assay, from the lowest: compounds 3, 2 and 1 (each within the scatter of the next, the first and the last beyond it).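

In this assay, the exchange of 4-chlorophenyl to 4-methoxyphenyl now has a single-change reading of a 1.3-fold lower number from compound 2 to compound 3 (0.12 log units; within the scatter) and, with the ethynyl-bearing chain on the nitrogen, chloro and methoxy at this place on the aromatic ring cannot be told apart. Among the compounds shown here, the series also gains its first reading on the nitrogen substituent: with methoxy held on the ring, ethynyl in place of methyl on the saturated chain carbon gives a 2.3-fold lower number from compound 1 to compound 3 (0.37 log units; beyond the scatter) and is the only single-change step so far that lies beyond the scatter, though it is modest in size. No measurement at hand accounts for the size of either step.

On these data alone, the step on the nitrogen substituent is read only with methoxy on the ring, so whether it holds with chloro there stays open, as does its reading on any other form of the shared core. As far as these compounds go, how far either site can be changed is also open, for instance with a longer chain on the nitrogen, or with an amine or a carboxylic acid in place of chloro and methoxy on the ring.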